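The source may report more compounds than this note shows. Statements on the series, on what has been measured and on what is new or still open speak of the compounds shown alone.

Compound 1 `COc1ccc(CNC(=O)c2c(C)nc3cc(C)ccn23)cc1` and compound 2 `COc1cccc(CNC(=O)c2c(C)nc3cc(C)ccn23)c1` share a core and have both been tested in a whole animal. In an in vivo ADME assay on the whole organism (strain Sprague-Dawley) for pharmacokinetics, with Rattus norvegicus as the target, at a dose of 10 mg/kg by the oral route (on this read-out lower numbers stand for lower oral bioavailability and higher numbers for higher oral bioavailability), compound 1 gives 50% and compound 2 gives 43% on the same scale. These two numbers lie within the usual scatter of repeated measurements, so compound 1 stands level with compound 2 and the pair cannot be ranked. Compound 3 `Cc1ccn2c(C(=O)NCc3ccc(Cl)cc3)c(C)nc2c1` has not been measured yet. It has chloro in place of methoxy on an aromatic carbon of compound 1, para to a large group (chloro in place of methoxy on an aromatic carbon). Within the data shown here, no measured pair here shows what a single swap of this kind does, so the expectation has little to lean on and the range has to stay wide. Starting from compound 1 at 50% no step beyond the scatter is expected in this assay in either direction. The estimated change is therefore small (a number 4 percentage points lower from compound 1 to compound 3 (within the scatter)). In this assay compound 3 is estimated at 46% with a likely range of 26% to 66% for now.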

Compound 3, oral bioavailability: 49%
For compound 3 the middle estimate is 3 percentage points below the measured one, within the range that was stated.
By their numbers in this assay, from the lowest: compounds 2, 3 and 1 (each within the scatter of the next).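

In this assay, replacing methoxy with chloro on the aromatic carbon para to a large group gives a number 1 percentage points lower from compound 1 to compound 3 (within the scatter), the first single-place step available for this position, and it lies within the scatter. For this pair, then, a group of two heavy atoms with one hydrogen-bond acceptor gives way to a single chlorine atom with no hydrogen-bond acceptor, and the read-out shows no change that can be told apart from repeat-measurement noise. Nothing measured here accounts for this lack of a visible change.

Among these compounds, whether this position stays as tolerant with a group of a different kind, such as an amine, a carboxylic acid or a longer chain like butoxy, remains open, since methoxy and chloro are the only two groups compared there in a single-place step. From the compounds shown here alone, it is also open whether the same swap would give a similar result elsewhere on the molecule, because one step at one position cannot be carried over to other sites on the shared core.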